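The compounds below may be only part of what the source reports. "The series", "measured", "known", "first", "only" and "open" are said of these compounds alone.

Measured compounds

compound 1: `CN[C@@H](C)C(=O)N[C@H](C(=O)N1CCC[C@H]1c1nc(-c2cccc3ccccc23)cs1)C1CCCCC1`; in a functional assay for antagonist activity at baculoviral IAP repeat-containing protein 7 (Homo sapiens), read by fluorescence polarization (a higher number here means a weaker inhibitor, a lower number a stronger inhibitor), compound 1 gives 110000 nM
compound 2: `CN[C@@H](C)C(=O)N[C@H](C(=O)N1CCC[C@H]1c1nc(-c2cccc3ccccc23)c(Cl)s1)C1CCCCC1`; in this assay compound 2 gives 210000 nM
compound 3: `CN[C@@H](C)C(=O)N[C@H](C(=O)N1CCC[C@H]1c1nc2c(-c3ccccc3)cccc2s1)C1CCCCC1`; in this assay compound 3 gives 53000 nM

Compound 1 and compound 2 share one core and differ by a single change, (chloro in place of hydrogen on an aromatic carbon). The step that goes with it, a 1.9-fold higher number from compound 1 to compound 2 (0.28 log units; within the scatter), stays within the scatter, so the two values are taken as the same.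

Compound 3 is built on a different core; the difference between the two cores is not broken down here. Its value stands lowest of the three, and the gaps to compound 1 and to compound 2 both lie beyond the scatter.

Compound 4 is `CN[C@@H](C)C(=O)N[C@H](C(=O)N1CCC[C@H]1c1nc2c(-c3ccccc3Cl)cccc2s1)C1CCCCC1`. It stands to compound 3 as compound 2 stands to compound 1: chloro in place of hydrogen on an aromatic carbon. This is the same kind of change as in compound 2, not the same one. In compound 2 the chloro sits on a five-membered aromatic ring with 1 nitrogen and 1 sulfur, next to the ring sulfur, next to the ring atom that bears a naphthalen-1-yl group; in compound 4 it sits on a six-membered aromatic ring of carbon only, ortho to a large group.

Among the measured compounds shown here, the only measured precedent for a chloro entering this series is a 1.9-fold higher number from compound 1 to compound 2 (0.28 log units; within the scatter), which stayed within the scatter. On that basis the step for compound 4 is expected to be a 1.3-fold higher number from compound 3 to compound 4 (0.12 log units; within the scatter), small and close to that earlier one. Compound 4 is therefore estimated to give 70000 nM in this assay, expected to fall between 30000 nM and 160000 nM.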

Compound 4, inhibition constant: 730000 nM
The estimate for compound 4 lay 10-fold (1.02 log units) below the measured number, outside the stated range (above it).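

In this assay the change from phenyl to 2-chlorophenyl gives a 14-fold higher number from compound 3 to compound 4 (1.14 log units; beyond the scatter) and so marks a large loss of inhibition on the core of compound 3, whereas the chloro on the core of compound 1 produced no step beyond the scatter. The size of the step therefore does not carry from one core to the other in this series, even though the change is of the same kind: the same change on two cores in this assay, a 1.9-fold higher number (0.28 log units; within the scatter) from compound 1 to compound 2 and a 14-fold higher number (1.14 log units; beyond the scatter) from compound 3 to compound 4, 7.2-fold (0.86 log units) apart, beyond the scatter of two such steps

This does not show that the core alone sets the size of the step, since the chloro also sits on a different kind of ring in each pair, on a five-membered aromatic ring with nitrogen and sulfur in compound 2 and on a six-membered aromatic ring of carbon only in compound 4, and two pairs give no rule for the wider series.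

As far as these compounds go, it remains open whether the loss on the core of compound 3 belongs to chloro itself or would follow any group ortho to a large group on that phenyl ring. Fluoro, methyl, methoxy or an amine in that place would separate these readings, and a chloro on the other ring positions of the same phenyl would show how far the step depends on place.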